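From pentyloxy to isobutoxy on a shared core

A few compounds are considered here, and "the series" means these few. Any claim that something is new, unique, unknown or untested is made for them only; others in the source may bear on it.

Measured in a functional assay on DLD-1 cells (Homo sapiens) for cytotoxicity, with a stated time of 48 h (on this read-out higher numbers stand for weaker inhibition and lower numbers for stronger inhibition), so far:
compound 1 `CCOc1ccc2oc(/C=C/[S+](C)[O-])cc(=O)c2c1` gives 4900 nM
compound 2 `CC(=O)Oc1ccc2oc(/C=C/[S+](C)[O-])cc(=O)c2c1` gives > 10000 nM as a limit of the assay
compound 3 `CCCCCOc1ccc2oc(/C=C/[S+](C)[O-])cc(=O)c2c1` gives 6600 nM

For the measured compounds named here, compound 3 lies within the scatter of compound 1, the only other plain number. Compound 4 `CC(C)COc1ccc2oc(/C=C/[S+](C)[O-])cc(=O)c2c1` is not yet measured. It carries isopropyl in place of butyl on a saturated chain carbon bound to an oxygen on an aromatic ring, which also reads as pentyl to isobutyl. The measured step that bears on this is the chain step a 1.3-fold higher number from compound 1 to compound 3 (0.13 log units; within the scatter), so no step beyond the scatter is expected in this assay. The expected step is a 1.2-fold lower number from compound 3 to compound 4 (0.08 log units; within the scatter), which is only an estimate. Compound 4 is estimated at 5500 nM, with an expected range of 2800 nM to 10000 nM.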

Compound 4, half-maximal inhibitory concentration: 5000 nM
Estimate against measurement, compound 4: 1.1-fold (0.04 log units) above, within the range that was stated.
By their numbers in this assay, from the lowest: compounds 1, 4 and 3 (each within the scatter of the next). At a limit, above all of these: compound 2.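

In this assay, the branched isobutyl on this oxygen on an aromatic ring cannot be told apart from the straight pentyl or ethyl chains, with a 1.3-fold lower number from compound 3 to compound 4 (0.12 log units; within the scatter) and a 1.0-fold higher number from compound 1 to compound 4 (0.01 log units; within the scatter). Against the acetyl of compound 2, the result is an at least 2.0-fold lower number from compound 2 to compound 4 (0.30 log units; that floor lies within the scatter), and that step rests on a limit of the assay rather than a number. Compound 2 alone stands at this limit: the limit of > 10000 nM in this assay, at which 1 of the 4 values shown sits.

As far as these compounds go, whether an amine, a carboxylic acid or a phenyl group on this oxygen would move the number beyond the scatter stays open.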